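(Thiophen-2-yl)sulfonyl in place of benzyloxycarbonyl: working notes

The source may hold more compounds than are shown below. What is called first, only, known or untested is meant among the compounds shown, and "the series" means these compounds.

Two members of the series have so far been taken through an ADME assay on microsomes from liver (Homo sapiens) for metabolic stability, read by LC-MS, with NADPH named in the record, with a stated time of 60 min, tested at 1 uM, in the absence of a further agent; on this read-out higher numbers stand for a more stable compound and lower numbers for a less stable compound. Compound 1 `CC(=O)N[C@@H]1CCN(c2cc(C)nn3c(-c4ccco4)c(C)nc23)C1` returns a value that is a limit of the assay rather than a number, > 95%. Compound 2 `COc1ccc(-c2c(C)nc3c(N4CC[C@@H](NC(=O)OCc5ccccc5)C4)cc(C)nn23)cc1OC` likewise returns only a limit, > 95%. Compound 2 therefore stands at the limit of > 95% in this assay, at which 2 of the 2 values shown sit; no number separates it from compound 1, and the two results give no order between them.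

Compound 3 `COc1ccc(-c2c(C)nc3c(N4CC[C@@H](NS(=O)(=O)c5cccs5)C4)cc(C)nn23)cc1OC` differs from compound 2 in a single place: (thiophen-2-yl)sulfonyl in place of benzyloxycarbonyl on an amine nitrogen. Among the measured compounds shown here, no pair of measured compounds carries this change, so there is no measured step to lean on, and the only anchor is compound 2 at the limit of this assay. The expected step is a number at least 5 percentage points lower from compound 2 to compound 3 (that floor lies within the scatter), which is within the scatter, with any movement only downward since compound 2 cannot be read higher. Compound 3 is accordingly estimated at 90% in this assay, with a range from 70% to 99%; a further read at the limit would not be a surprise.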

Compound 3, percent of the compound remaining: > 95%
Compound 3 was reported as a limit (the forecaster's own chance of this, stated with the estimate: 50%); middle value at least 5 percentage points away from the limit.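

In this assay no step can be read between compound 2 and compound 3, as both results are limits and not numbers: the limit of > 95% in this assay, at which 3 of the 3 values shown sit.

The compounds shown leave open whether (thiophen-2-yl)sulfonyl in place of benzyloxycarbonyl on an amine nitrogen changes the percent of compound remaining at all, and what order compound 1, compound 2 and compound 3 would take.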